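A benzimidazolylmethyl group replaces chlorophenyl on the triazole nitrogen

The source may hold more compounds than are shown below. What is called first, only, known or untested is meant among the compounds shown, and "the series" means these compounds.

Compound 2 `CN(CCNCc1cn(-c2ccccc2Cl)nn1)CCNc1ccnc2cc(Cl)ccc12` gives 12000 nM in a functional assay on HCC827 cells (Homo sapiens) for antiproliferative activity, read by sulforhodamine B assay, with a stated time of 72 h; a lower number here means a stronger inhibitor, a higher number a weaker inhibitor. Among the three measured numbers it stands second highest: compound 1 `C#CCNCCN(C)CCNc1ccnc2cc(Cl)ccc12` gives 105000 nM, a gap from compound 2 that lies beyond the scatter, while compound 3 `CN(CCNCc1cn(Cc2ccc(Br)cc2)nn1)CCNc1ccnc2cc(Cl)ccc12` gives 9300 nM, and the step of a 1.3-fold lower number from compound 2 to compound 3 (0.11 log units; within the scatter). Compound 4 `CN(CCNCc1cn(Cc2nc3ccccc3[nH]2)nn1)CCNc1ccnc2cc(Cl)ccc12` differs from compound 2 by (1H-benzimidazol-2-yl)methyl in place of 2-chlorophenyl on an aromatic nitrogen. Among the compounds with values here, only one measured step changes the group on that aromatic nitrogen, and a 1.3-fold lower number from compound 2 to compound 3 (0.11 log units; within the scatter) showed that such an exchange moved the number little. Within the data shown here, no measured compound carries the benzimidazole, so the effect of the entering group itself is not known from these data. Among the measured compounds shown here, since the one comparable step stayed within the scatter, the expected step is a 1.2-fold lower number from compound 2 to compound 4 (0.08 log units; within the scatter), which is not expected to exceed the scatter. Compound 4 is accordingly estimated at 10000 nM in this assay, with a range from 4000 nM to 30000 nM.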

Compound 4, half-maximal inhibitory concentration: 164000 nM
Compound 4: the middle estimate sits 16-fold (1.21 log units) below what was measured; measured number above the stated range.
By their numbers in this assay, from the lowest: compounds 3 and 2 (each within the scatter of the next); then compounds 1 and 4 (each within the scatter of the next).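

In this assay, the aromatic nitrogen of the five-membered aromatic ring with 3 nitrogen proves sensitive to the group it carries: (1H-benzimidazol-2-yl)methyl in place of 2-chlorophenyl gives a large step (a 14-fold higher number from compound 2 to compound 4 (1.14 log units; beyond the scatter)), whereas the earlier exchange at this nitrogen stayed within the scatter. With the saturated chain carbon present in both compounds, 1H-benzimidazol-2-yl in place of 4-bromophenyl also gives a large step (an 18-fold higher number from compound 3 to compound 4 (1.25 log units; beyond the scatter)), so that carbon alone does not account for the change. No measurement available here explains either step.

The compounds shown leave open whether the ring nitrogens of the benzimidazole are tied to these steps. An unsubstituted benzyl or an indolylmethyl group on the same aromatic nitrogen would separate the ring nitrogens from the fused bicyclic shape.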